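A few compounds are considered here, and "the series" means these few. Any claim that something is new, unique, unknown or untested is made for them only; others in the source may bear on it.

Compound 2, `Cc1c(C(=O)N/N=C\c2ccccc2)oc2cccc(O)c12`, and compound 1, `Cc1c(C(=O)N/N=C\c2ccc(O)cc2)oc2cccc(O)c12`, share one core and differ only on the six-membered aromatic ring of carbon only that hangs from the hydrazone. In a functional assay on PC-3 cells (Homo sapiens) for inhibition (a higher number here means a weaker inhibitor, a lower number a stronger inhibitor), compound 1 gives 21700 nM, and compound 2 gives 29200 nM; the step of a 1.3-fold higher number from compound 1 to compound 2 (0.13 log units; within the scatter) lies within the usual scatter, so the two numbers cannot be told apart, and compound 2 simply gives the larger of the two figures without standing apart from compound 1.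

Going by the values given here, compound 3, `COc1cccc(/C=N\NC(=O)c2oc3cccc(O)c3c2C)c1`, arises from compound 2 by the change (methoxy in place of hydrogen on an aromatic carbon), a substituent on the same ring of carbon only that the one measured step touched. Among the compounds with values here, that step, from hydroxy to hydrogen, stayed within the scatter, and no measured pair speaks to a methoxy group. On this basis no step beyond the scatter is expected in this assay, and compound 3 is estimated at 26000 nM, with a range from 10000 nM to 65000 nM, which would be an expected step of a 1.1-fold lower number from compound 2 to compound 3 (0.05 log units; within the scatter).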

Compound 3, half-maximal inhibitory concentration: >= 40000 nM
Compound 3: only a limit was reported (the forecaster's own chance of this, stated with the estimate: 10%); middle value at least 1.5-fold (0.18 log units) away from the limit.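

In this assay compound 3 gives only a limit, >= 40000 nM, and not a number: the limit of >= 40000 nM in this assay, at which 1 of the 3 values shown sits. Read as floors, the steps are an at least 1.3-fold higher number from compound 2 to compound 3 (0.13 log units; that floor lies within the scatter) and an at least 1.8-fold higher number from compound 1 to compound 3 (0.26 log units; that floor lies within the scatter), and since neither floor clears the scatter, the data do not set compound 3 apart from compound 1 or compound 2, while the true size of either step stays unknown. Going by these compounds alone, what the result adds is that phenyl to 3-methoxyphenyl is the first change on this ring to end in a limit rather than a number, so a substituent at this place can no longer be said to leave the read-out as a plain figure, as the step between hydrogen and hydroxy did.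

The compounds shown leave open whether a different group at this same place, such as an amine, a chlorine atom or a carboxylic acid, would return a number or another limit. They also leave open whether a longer chain on the oxygen, in place of methoxy, would read any differently in this assay.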